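From a Pentyl Chain to a Phenyl Ring

The source may report more compounds than this note shows. Statements on the series, on what has been measured and on what is new or still open speak of the compounds shown alone.

Compound 1 `CCCCCCc1nc2ccccc2[nH]1` gives 32400 nM in an ADME assay on microsomes from liver for inhibition of cytochrome P450 2B1 (Rattus norvegicus); on this read-out lower numbers stand for stronger inhibition and higher numbers for weaker inhibition.
Compound 2 `CCCCCCCCc1nc2ccccc2[nH]1` gives 28800 nM.
Compound 3 `CCCCCCCCCCCCCc1nc2ccccc2[nH]1` gives 22900 nM.

All three share one core and differ only in the length of the chain on it. In this assay compound 2 stands second highest of the three numbers, nearest to compound 1 and furthest from compound 3. The measured steps were a 1.1-fold lower number from compound 1 to compound 2 (0.05 log units; within the scatter), a 1.3-fold lower number from compound 2 to compound 3 (0.10 log units; within the scatter) and a 1.4-fold lower number from compound 1 to compound 3 (0.15 log units; within the scatter), each within the scatter.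

Compound 4 `c1ccc(CCCc2nc3ccccc3[nH]2)cc1` brings a different kind of change: phenyl in place of pentyl on a saturated chain carbon, three bonds along the chain from an aromatic carbon. Going by the values given here, no measured step exchanges a chain for a ring; the measured steps only show that lengthening the chain leaves the numbers within the scatter. Nothing beyond the scatter is therefore expected here. The expected step is a 1.0-fold lower number from compound 2 to compound 4 (0.01 log units; within the scatter). Compound 4 is estimated at 28000 nM, with a range from 12000 nM to 65000 nM.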

Compound 4, half-maximal inhibitory concentration: 19100 nM
The estimate for compound 4 lay 1.5-fold (0.17 log units) above the measured number; the measured number falls inside the stated range.
By their numbers in this assay, from the lowest: compounds 4, 3, 2 and 1 (each within the scatter of the next).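

In this assay phenyl in place of pentyl, three bonds along the chain from an aromatic carbon, gives one step (a 1.5-fold lower number from compound 2 to compound 4 (0.18 log units; within the scatter)), and phenyl in place of propyl gives another (a 1.7-fold lower number from compound 1 to compound 4 (0.23 log units; within the scatter)). A ring at this place therefore stays within the scatter, as the changes of chain length did, which the chain compounds alone could not show. Nothing measured here bears on why this is so.

The compounds shown leave open whether an amine or a carboxylic acid at this place would move the number beyond the scatter.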